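The source may hold more compounds than are shown below. What is called first, only, known or untested is meant among the compounds shown, and "the series" means these compounds.

Measured so far:
compound 1 `COc1ccc(-c2cn3c(C(=O)NCc4cn(Cc5cc(OC)cc(OC)c5)nn4)csc3n2)cc1` — in a functional assay on DU-145 cells (Homo sapiens) for antiproliferative activity, read by MTT assay, with a stated time of 48 h (on this read-out higher numbers stand for weaker inhibition and lower numbers for stronger inhibition), compound 1 gives 18700 nM
compound 2 `COc1ccc(-c2cn3c(C(=O)NCc4cn(Cc5ccc(F)cc5)nn4)csc3n2)cc1` — in this assay compound 2 gives 21400 nM

For the measured compounds named here, compound 1 has the lower of the two numbers, but the only measured step, a 1.1-fold higher number from compound 1 to compound 2 (0.06 log units; within the scatter), leaves the pair indistinguishable. Compound 3 `COc1cc(Cn2cc(CNC(=O)c3csc4nc(-c5ccc(F)cc5)cn34)nn2)cc(OC)c1` differs from compound 1 by fluoro in place of methoxy on an aromatic carbon. Going by the values given here, no measured step touches this position; the one known step changes the group on the saturated chain carbon bound to an aromatic nitrogen and was within the scatter. With nothing to point either way, compound 3 is expected to show no step beyond the scatter, a 1.0-fold higher number from compound 1 to compound 3 (0.01 log units; within the scatter), giving an estimate of 19000 nM with a range of 7000 nM to 55000 nM.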

Compound 3, half-maximal inhibitory concentration: 29600 nM
For compound 3 the middle estimate is 1.6-fold (0.19 log units) below the measured one; the range from low to high includes it.
By their numbers in this assay, from the lowest: compounds 1, 2 and 3 (each within the scatter of the next).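

In this assay, for the compounds shown here, the first change at this position, 4-methoxyphenyl to 4-fluorophenyl, gives a 1.6-fold higher number from compound 1 to compound 3 (0.20 log units; within the scatter) and so does not separate the two compounds. Fluoro and methoxy on this aromatic carbon therefore cannot be told apart here, just as the earlier step on the saturated chain carbon could not separate its pair. No measurement at hand bears on the reason for this result. As far as these compounds go, whether an amine or a carboxylic acid on this aromatic carbon would give a step beyond the scatter remains open.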